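The source may report more compounds than this note shows. Statements on the series, on what has been measured and on what is new or still open speak of the compounds shown alone.

Compound 2 `CC(C)c1noc(N2CCN(C(=O)[C@@H]3CCCN(S(=O)(=O)c4ccc(S(=O)(=O)NC5CC5)cc4)C3)CC2)n1` gives the highest of the two numbers recorded in a functional assay on MIA PaCa-2 cells (Homo sapiens) for inhibition, read by MTT assay, with a stated time of 7 days; a lower number here means a stronger inhibitor, a higher number a weaker inhibitor: in this assay compound 2 gives 1000 nM. The other, compound 1 `CCN(CC)S(=O)(=O)c1ccc(S(=O)(=O)N2CCC[C@@H](C(=O)N[C@@H]3CCN(C(=O)OC(C)(C)C)C3)C2)cc1`, is built differently in several places, and in this assay compound 1 gives 200 nM, a markedly lower number. Compound 3 `CCC(CC)S(=O)(=O)c1ccc(S(=O)(=O)N2CCC[C@@H](C(=O)N3CCN(c4nc(C(C)C)no4)CC3)C2)cc1` is still unmeasured; it carries pentan-3-yl in place of cyclopropylamino on a sulfonyl sulfur, that is, pentan-3-yl in place of cyclopropylamino on a sulfonyl sulfur. Within the data shown here, no measured pair shows this exact change, so only a modest step is expected, estimated as a 1.4-fold lower number from compound 2 to compound 3 (0.15 log units; within the scatter). For compound 3 the expected value is 700 nM, within a range of 200 nM to 2500 nM.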

Compound 3, half-maximal inhibitory concentration: 50 nM
For compound 3 the middle estimate is 14-fold (1.15 log units) above the measured one; measured number below the stated range.
By their numbers in this assay, from the lowest: compound 3; then compound 1; then compound 2.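

Replacing cyclopropylamino with pentan-3-yl on a sulfonyl sulfur gives a 20-fold lower number from compound 2 to compound 3 (1.30 log units; beyond the scatter) in this assay, so this position strongly affects the number. The change removes a ring and the only hydrogen-bond donor in the group, yet the result does not show which of these differences matters. No measurement here explains the step.

The compounds shown leave open whether the nitrogen or the open carbon chain accounts for it. A cyclopentyl group on the same sulfonyl sulfur would help separate these two differences.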